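Amino in Place of Hydroxy, Tried on a Second Core

The source may report more compounds than this note shows. Statements on the series, on what has been measured and on what is new or still open speak of the compounds shown alone.

Compound 1 `COc1ccc(C(=O)c2ccc3c(c2)C=CC(C)(C)O3)c(NC(=O)CO)c1` and compound 2 `COc1ccc(C(=O)c2ccc3c(c2)C=CC(C)(C)O3)c(NC(=O)CN)c1` share one core, while compound 3 `C=C(c1ccc(OC)cc1NC(=O)CO)c1ccc(OC)c2c1C=CC(C)(C)O2` and the as yet unmeasured compound 4 `C=C(c1ccc(OC)cc1NC(=O)CN)c1ccc(OC)c2c1C=CC(C)(C)O2` share another; how the core of compound 3 differs from that of compound 1 is not broken down here. In a functional assay on MCF7 cells (Homo sapiens) for antiproliferative activity, read by MTT assay, with a stated time of 48 h (on this read-out higher numbers stand for weaker inhibition and lower numbers for stronger inhibition), compound 1 gives 200 nM, compound 2 gives 680 nM, and compound 3 gives 590 nM. Among the compounds with values here, the single change that has been measured, (amino in place of hydroxy on a saturated chain carbon bound to a carbonyl carbon), produced the step of a 3.4-fold higher number from compound 1 to compound 2 (0.53 log units; beyond the scatter). The change from compound 3 to compound 4 is amino in place of hydroxy on a saturated chain carbon bound to a carbonyl carbon, and since the two place descriptions read the same word for word, it is the same kind of change carried onto the second core. On the first core it pushed the number modestly toward weaker inhibition, beyond the scatter. On that one earlier step of a 3.4-fold higher number from compound 1 to compound 2 (0.53 log units; beyond the scatter), and on compound 3 standing at 590 nM, compound 4 is expected to move by about a 3.4-fold higher number from compound 3 to compound 4 (0.53 log units; beyond the scatter) in this assay. Within the data shown here, the estimate for compound 4 is therefore 2000 nM, with a plausible range from 800 nM to 5000 nM, a range kept wide since only one earlier instance of the change exists.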

Compound 4, half-maximal inhibitory concentration: 780 nM
Compound 4: the middle estimate sits 2.6-fold (0.41 log units) above what was measured; the measured number lies below the stated range.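

In this assay, the step on the second core reads a 1.3-fold higher number from compound 3 to compound 4 (0.12 log units; within the scatter), so amino in place of hydroxy on a saturated chain carbon bound to a carbonyl carbon does not separate this pair, whereas the same change on the first core did separate its pair. Even so, the two steps cannot be told apart from one another: the same change on two cores in this assay, a 3.4-fold higher number (0.53 log units; beyond the scatter) from compound 1 to compound 2 and a 1.3-fold higher number (0.12 log units; within the scatter) from compound 3 to compound 4, 2.6-fold (0.41 log units) apart, within the scatter of two such steps

The result therefore shows that the two cores give no measurable disagreement about this change, but it does not show that the change has the same size on both, nor that the core alters its size, since each core offers a single pair.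

The compounds shown leave open whether the cores would part ways with other groups on this chain, such as a dimethylamino group or a carboxylic acid. They also leave open how a longer chain, with the amino or hydroxy group set further from the carbonyl, would behave on either core.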